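A few compounds are considered here, and "the series" means these few. Any claim that something is new, unique, unknown or untested is made for them only; others in the source may bear on it.

Measured compounds:
compound 1 `CN1CC2(CC(S(=O)(=O)c3c(Cl)ccc(NC(=O)Nc4cccc(F)c4Cl)c3O)C2)C1` — 1050 ng.h/mL
compound 2 `C[C@@H]1CN(S(=O)(=O)c2c(Cl)ccc(NC(=O)Nc3cccc(F)c3Cl)c2O)C[C@H](C)O1` — 279 ng.h/mL
compound 3 `CN1CC[C@H](S(=O)(=O)c2c(Cl)ccc(NC(=O)Nc3cccc(F)c3Cl)c2O)C1` — 432 ng.h/mL

In an ADME assay on the whole organism (blood, Mus musculus, strain C57BL/6) for pharmacokinetics, read by HPLC, with a stated time of 4 h, at a dose of 2 mg/kg by the intraperitoneal route (on this read-out lower numbers stand for lower exposure and higher numbers for higher exposure at the dose given), compound 1 gives 1050 ng.h/mL, compound 2 gives 279 ng.h/mL and compound 3 gives 432 ng.h/mL. Compound 3 stands second highest of the three numbers; its nearest neighbour is compound 2, within the scatter, and the furthest is compound 1, beyond the scatter.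

The new compound 4 `CCN1CCN(S(=O)(=O)c2c(Cl)ccc(NC(=O)Nc3cccc(F)c3Cl)c2O)CC1` differs from compound 3 in one place: 4-ethylpiperazin-1-yl in place of 1-methylpyrrolidin-3-yl on a sulfonyl sulfur.

Within the data shown here, three measured steps bear on this change. From the spiro group of compound 1 the step of a 3.8-fold lower number from compound 1 to compound 2 (0.58 log units; beyond the scatter) and the step of a 2.4-fold lower number from compound 1 to compound 3 (0.39 log units; beyond the scatter) both lowered exposure in this assay, while the step of a 1.5-fold higher number from compound 2 to compound 3 (0.19 log units; within the scatter) lies within the scatter. The six-membered ring with 2 hetero atoms entering in compound 4 most resembles the 2,6-dimethylmorpholin-4-yl of compound 2, and compound 2 and compound 3 are within the scatter of each other. The account therefore expects no step beyond the scatter, perhaps a slight downward drift, in this assay for compound 4, meaning a 1.2-fold lower number from compound 3 to compound 4 (0.09 log units; within the scatter). Compound 4 is thus estimated at 350 ng.h/mL, with a range from 150 ng.h/mL to 800 ng.h/mL.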

Compound 4, area under the concentration-time curve: 189 ng.h/mL
Compound 4: the middle estimate sits 1.9-fold (0.27 log units) above what was measured; low and high end bracket the measured number.
By their numbers in this assay, from the lowest: compounds 4, 2 and 3 (each within the scatter of the next, the first and the last beyond it); then compound 1.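

In this assay the change on the sulfonyl sulfur to 4-ethylpiperazin-1-yl gives a 2.3-fold lower number from compound 3 to compound 4 (0.36 log units; beyond the scatter) and thus a step beyond the scatter, which shows that exposure at this position can still move when one small ring with a basic-looking name gives way to another, though nothing here says what drives it. Against the other six-membered ring the reading is a 1.5-fold lower number from compound 2 to compound 4 (0.17 log units; within the scatter) and lies within the scatter, so 4-ethylpiperazin-1-yl and 2,6-dimethylmorpholin-4-yl cannot be told apart here, although only compound 4 stands beyond the scatter from compound 3. The distance from the spiro group also widens, with a 5.6-fold lower number from compound 1 to compound 4 (0.74 log units; beyond the scatter) as the largest step at this position so far, and no further measurement shown bears on why these groups differ.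

On these data alone, whether a 4-methylpiperazin-1-yl or an unsubstituted piperazin-1-yl would stay with compound 4 or come closer to compound 3 remains open. As far as these compounds go, it also remains open whether a morpholin-4-yl without the two methyl groups would sit with compound 2, and whether any of these groups could approach the spiro group of compound 1.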